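The compounds below may be only part of what the source reports. "The series", "measured", "known", "first", "only" and "open" are said of these compounds alone.

Compound 1 `Cn1nc2c(=O)n(CC3(O)CCN(Cc4ccc(-c5ccco5)cc4Cl)CC3)cnc2c1-c1ccc(C2(N)CC2)cc1`: 66.1 nM
Compound 2 `Cn1nc2c(=O)n(CC3(O)CCN(Cc4ccc(-c5ccncc5)cc4Cl)CC3)cnc2c1-c1ccc(CN)cc1`: 257 nM
Compound 3 `Cn1nc2c(=O)n(CC3(O)CCN(Cc4ccc(-c5ccsc5)cc4Cl)CC3)cnc2c1-c1ccc(CN)cc1`: 59.5 nM

Of the compounds shown here, three built on the same core have been tested in an assay on isolated protein for inhibition of ubiquitin carboxyl-terminal hydrolase 7 (Homo sapiens), with stated times of 30 min and 2 h; a higher number here means a weaker inhibitor, a lower number a stronger inhibitor. Compound 1 gives the second highest of the three numbers. Its nearest neighbour is compound 3 with 59.5 nM, a gap that lies within the scatter, so the two cannot be ranked against each other. Compound 2, with 257 nM, stands furthest from compound 1, and that gap lies beyond the scatter. Going by the values given here, the only step between two compounds that differ in a single place is a 4.3-fold lower number from compound 2 to compound 3 (0.64 log units; beyond the scatter), a modest change, and it concerns a different part of the structure than the change followed here.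

Compound 4 `Cn1nc2c(=O)n(CC3(O)CCN(Cc4ccc(-c5ccco5)cc4Cl)CC3)cnc2c1-c1ccc(C(=N)N)cc1` differs from compound 1 by a group of 3 heavy atoms (1 carbon, 2 nitrogen; no ring) in place of a group of 4 heavy atoms (3 carbon, 1 nitrogen; one three-membered non-aromatic ring of carbon only), on an aromatic carbon. Among the compounds with values here, no measured pair exchanges a group at this place, so none of the steps bears directly on it; the data offer no guide as to size or direction. In this situation the closest anchor is the value of compound 1, 66.1 nM, and no step beyond the scatter is expected. Compound 4 is therefore estimated to give 80 nM, within a range from 25 nM to 250 nM. That estimate corresponds to an expected step of a 1.2-fold higher number from compound 1 to compound 4 (0.08 log units; within the scatter).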

Compound 4, half-maximal inhibitory concentration: 87.5 nM
Beside the measured number, compound 4's estimate is 1.1-fold (0.04 log units) below it, within the range that was stated.
By their numbers in this assay, from the lowest: compounds 3, 1 and 4 (each within the scatter of the next); then compound 2.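

In this assay, the exchange on an aromatic carbon of a six-membered aromatic ring of carbon only, para to a large group, gives a 1.3-fold higher number from compound 1 to compound 4 (0.12 log units; within the scatter), so this first single-place comparison at this position shows no difference that can be read. The exchange removes the 1-aminocyclopropyl group with its three-membered ring and puts in a group with no ring, a double bond outside aromatic rings and, by the count, one more hydrogen-bond donor, yet the two compounds cannot be ranked against each other. No measurement shown offers an explanation for this result.

The pair leaves open whether a carboxylic acid, a nitrile or a longer chain such as 2-aminoethyl at this position would stay equally close to compound 1. It also leaves open how an aminomethyl group compares with these two groups, since compound 2 and compound 3 carry that group but differ from compound 1 in more than one place.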